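Amide nitrogen substituents on a dialkoxybenzamide phosphodiesterase series

The compounds below may be only part of what the source reports. "The series", "measured", "known", "first", "only" and "open" are said of these compounds alone.

Measured so far:
compound 1, `COc1ccc(C(=O)Nc2ccccc2O)cc1OC1CCCC1`: 1300 nM
compound 2, `COc1ccc(C(=O)Nc2ccccn2)cc1OC1CCCC1`: 1000 nM

In an assay on isolated protein for inhibition of phosphodiesterase 4A (Sus scrofa) (on this read-out lower numbers stand for stronger inhibition and higher numbers for weaker inhibition), compound 2 gives 1000 nM, the lower of the two numbers, though its step of a 1.3-fold lower number from compound 1 to compound 2 (0.11 log units; within the scatter) lies within the scatter. Compound 3, `COc1ccc(C(=O)Nc2c(Br)cncc2Br)cc1OC1CCCC1`, carries the change (3,5-dibromopyridin-4-yl in place of pyridin-2-yl on an amide-type nitrogen). Within the data shown here, no measured step touches that position in a comparable way; the only step known, from compound 1 to compound 2, was within the scatter. The estimate for compound 3 therefore rests on compound 2 alone, with a wide range: expected 400 nM, between 20 nM and 3000 nM, a step of a 2.5-fold lower number from compound 2 to compound 3 (0.40 log units; beyond the scatter) that is expected rather than supported.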

Compound 3, half-maximal inhibitory concentration: 7 nM
Compound 3: the middle estimate sits 57-fold (1.76 log units) above what was measured, and the stated range ends above it.
By their numbers in this assay, from the lowest: compound 3; then compounds 2 and 1 (each within the scatter of the next).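

In this assay the substituent on the amide-type nitrogen turns out to be a position of large effect: 3,5-dibromopyridin-4-yl in place of pyridin-2-yl gives a 140-fold lower number from compound 2 to compound 3 (2.15 log units; beyond the scatter) and in place of 2-hydroxyphenyl gives a 190-fold lower number from compound 1 to compound 3 (2.27 log units; beyond the scatter) in the same series. The earlier pair, whose step lies within the scatter, gave no sign of such a range. Nothing measured here bears on the origin of these steps.

From the compounds shown here alone, how the step divides between the two bromine atoms and the change from pyridin-2-yl to a pyridin-4-yl group remains open. Plain pyridin-4-yl or 3,5-dichloropyridin-4-yl would bear on that.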